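The source may report more compounds than this note shows. Statements on the series, on what has been measured and on what is new or still open speak of the compounds shown alone.

Measured so far in a functional assay on PC-3 cells (Homo sapiens) for antiproliferative activity, read by MTT assay, with a stated time of 48 h; a higher number here means a weaker inhibitor, a lower number a stronger inhibitor:
- compound 1 `C#Cc1cccc(Nc2ncnc3cc(NC(=O)/C=C/c4ccccc4)sc23)c1`, 700 nM
- compound 2 `N#Cc1cccc(Nc2ncnc3cc(NC(=O)/C=C/c4ccccc4)sc23)c1`, 540 nM

Among the measured compounds shown here, compound 2 cannot be separated from compound 1 on these numbers, as the only measured step is a 1.3-fold lower number from compound 1 to compound 2 (0.11 log units; within the scatter). Compound 3 `O=C(/C=C/c1ccccc1)Nc1cc2ncnc(Nc3ccc(F)c(Cl)c3)c2s1` is next, with the change (3-chloro-4-fluorophenyl in place of 3-cyanophenyl on a nitrogen on an aromatic ring), in words 3-chloro-4-fluorophenyl in place of 3-cyanophenyl on a nitrogen on an aromatic ring. For the measured compounds named here, no measured step covers this replacement. Going by the values given here, the only guide is the step with cyano in place of ethynyl on an aromatic carbon, which reached compound 2 as a 1.3-fold lower number from compound 1 to compound 2 (0.11 log units; within the scatter) and is a single small step. In this assay, no step beyond the scatter is therefore expected, and no direction can be called. For compound 3 the expected value is 500 nM, with an estimated range from 170 nM to 1500 nM. This estimate means an expected 1.1-fold lower number from compound 2 to compound 3 (0.03 log units; within the scatter) and leaves the wide range open.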

Compound 3, half-maximal inhibitory concentration: 200 nM
Beside the measured number, compound 3's estimate is 2.5-fold (0.40 log units) above it; the measured number falls inside the stated range.
By their numbers in this assay, from the lowest: compound 3; then compounds 2 and 1 (each within the scatter of the next).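

In this assay, among the compounds shown here, the aryl group on the nitrogen on an aromatic ring is the first place where a change moves the number beyond the scatter: 3-chloro-4-fluorophenyl gives a 2.7-fold lower number from compound 2 to compound 3 (0.43 log units; beyond the scatter), and against 3-ethynylphenyl it gives a 3.5-fold lower number from compound 1 to compound 3 (0.54 log units; beyond the scatter). Both steps are modest, yet they show that this place responds to replacing the whole substituted phenyl, whereas cyano in place of ethynyl left compound 1 and compound 2 within the scatter of each other. Nothing available explains the size or direction of these steps.

Compound 3 changes chlorine and fluorine together, so the compounds shown do not separate them, and a phenyl carrying only one of the two, or a methoxy or dimethylamino group, remains open. On these data alone, the amide side of the core stays the same throughout, so whether a saturated chain or a carboxylic acid there would keep this level also remains open.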